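The source may report more compounds than this note shows. Statements on the series, on what has been measured and on what is new or still open speak of the compounds shown alone.

Among the measured compounds shown here, compound 2 `CNC(=O)c1ccccc1-c1ccc([C@@H](C)Nc2nccc(C)c2NC(=O)CC(F)(F)F)cc1` sits in the middle of the three numbers so far in an ADME assay (Rattus norvegicus, strain Sprague Dawley) for metabolic stability; on this read-out higher numbers stand for a longer-lived compound and lower numbers for a shorter-lived compound: compound 2 gives 0.5 h, compound 1 `CNC(=O)c1ccccc1-c1ccc(CNc2ncccc2NC(=O)CC(F)(F)F)cc1` gives 0.3 h, and compound 3 `COC(=O)c1ccccc1-c1ccc([C@@H](C)Nc2nccc(C)c2NC(=O)CC(F)(F)F)cc1` gives 0.9 h. For the measured compounds named here, the only single-change step measured, a 1.8-fold higher number from compound 2 to compound 3 (0.26 log units; within the scatter), concerns the ester end of the molecule and does not touch the chain carbon changed here. Compound 4 `CNC(=O)c1ccccc1-c1ccc(CNc2nccc(C)c2NC(=O)CC(F)(F)F)cc1` differs from compound 2 by hydrogen in place of methyl on a saturated chain carbon bound to an aromatic carbon and a nitrogen on an aromatic ring. Compound 1 also lacks this methyl, but it lacks the ring methyl as well, so its difference from compound 2 is not a clean step; the two values of compound 1 and compound 2 in this assay are nonetheless close to each other. No measured step bears directly on the change, and nothing among these three compounds suggests a step beyond the scatter. The expected step from compound 2 to compound 4 is therefore a 1.3-fold lower number from compound 2 to compound 4 (0.10 log units; within the scatter), a small move downward at most. Compound 4 is estimated at 0.4 h, with a range from 0.2 h to 0.8 h.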

Compound 4, half-life: 1 h
Compound 4: the middle estimate sits 2.5-fold (0.40 log units) below what was measured, outside the stated range (above it).
By their numbers in this assay, from the lowest: compounds 1, 2, 3 and 4 (each within the scatter of the next, the first and the last beyond it).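

In this assay, hydrogen in place of methyl on the saturated chain carbon gives a 2.0-fold higher number from compound 2 to compound 4 (0.30 log units; within the scatter), so this position keeps the half-life of the series without the methyl, and the step stays within the scatter. Among the compounds shown here, the clean comparison that compound 1 and compound 2 could not offer now exists: with the chain carbon unchanged, methyl in place of hydrogen on an aromatic carbon gives a 3.3-fold higher number from compound 1 to compound 4 (0.52 log units; beyond the scatter), a modest step and the only single-change step so far beyond the scatter. No measurement at hand accounts for either step.

The compounds shown leave open whether the ring methyl gives a similar step when the chain methyl is present, and whether the methoxy-for-methylamino step carries over to compound 4. They also leave open how an ethyl or cyclopropyl group on the chain carbon, or a chlorine or methoxy group in place of the ring methyl, would read out.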